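Hydrazone aryl variation on the shared core: compound 4

The source may hold more compounds than are shown below. What is called first, only, known or untested is meant among the compounds shown, and "the series" means these compounds.

Compound 3 `CN(C)CCn1cnnc1-c1cc(Oc2ccc(NC(=O)N/N=C/c3ccc(O)cc3O)cc2F)ccn1` gives 12700 nM in a functional assay on A549 cells (Homo sapiens) for cytotoxicity, read by MTT assay, with a stated time of 72 h (on this read-out lower numbers stand for stronger inhibition and higher numbers for weaker inhibition), the highest number among the three measured compounds. Compound 1 `COc1ccc(OC)c(/C=N/NC(=O)Nc2ccc(Oc3ccnc(-c4nncn4CCN(C)C)c3)c(F)c2)c1` gives 1950 nM and compound 2 `CN(C)CCn1cnnc1-c1cc(Oc2ccc(NC(=O)N/N=C/c3ccc(F)cc3F)cc2F)ccn1` gives 1870 nM; the step of a 1.0-fold lower number from compound 1 to compound 2 (0.02 log units; within the scatter) is within the scatter, whereas a 6.5-fold higher number from compound 1 to compound 3 (0.81 log units; beyond the scatter) and a 6.8-fold higher number from compound 2 to compound 3 (0.83 log units; beyond the scatter) are beyond it. Compound 4 `CN(C)CCn1cnnc1-c1cc(Oc2ccc(NC(=O)N/N=C/c3cccc(O)c3)cc2F)ccn1` carries 3-hydroxyphenyl in place of 2,4-dihydroxyphenyl on a carbon with a double bond to nitrogen. Among the measured compounds shown here, no measured step goes from 2,4-dihydroxyphenyl to 3-hydroxyphenyl; the two steps into compound 3 bear on it only by showing that 2,4-dihydroxyphenyl sits beyond the other aryl groups. A modest move back toward compound 1 and compound 2 is expected, a 2.5-fold lower number from compound 3 to compound 4 (0.40 log units; beyond the scatter). Compound 4 is estimated at 5000 nM, within 1800 nM to 14000 nM.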

Compound 4, half-maximal inhibitory concentration: > 100000 nM
Compound 4: only a limit was reported (the forecaster's own chance of this, stated with the estimate: 5%); middle value at least 20-fold (1.30 log units) from the limit.
By their numbers in this assay, from the lowest: compounds 2 and 1 (each within the scatter of the next); then compound 3. At a limit, above all of these: compound 4.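

In this assay, compound 4 is reported only as a limit, not a number: the limit of > 100000 nM in this assay, at which 1 of the 4 values shown sits.
With 3-hydroxyphenyl in place of 2,4-dihydroxyphenyl on the carbon with a double bond to nitrogen, the series shows an at least 7.8-fold higher number from compound 3 to compound 4 (0.89 log units; beyond the scatter), so the two hydroxyl-bearing aryl groups are not interchangeable here. Against the aryl groups without hydroxyl, this position spans a far wider range than the earlier compounds showed: an at least 53-fold higher number from compound 2 to compound 4 (1.72 log units; beyond the scatter) and an at least 51-fold higher number from compound 1 to compound 4 (1.70 log units; beyond the scatter).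

From the compounds shown here alone, the actual value of compound 4 remains open. Also open, going by these compounds, is whether a methoxy group or an amine in place of the hydroxyl of 3-hydroxyphenyl would restore the numbers of compound 1 and compound 2.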